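Benzimidazole-free notes: S-substituent changes on a shared acid core

This account rests on a few compounds, and the source may have more. Where it says the series, first, only, none or still open, it means among the compounds named here.

Measured so far:
- compound 1 `CCCCCCSc1nc2ccccc2n1CC(=O)O`: 1360 nM
- compound 2 `CCCCCSc1nc2ccccc2n1CC(=O)O`: 1240 nM
- compound 3 `O=C(O)Cn1c(SCc2ccccc2Cl)nc2ccccc21`: 370 nM

In an assay on HEK293 cells for displacement of a labelled ligand from prostaglandin D2 receptor 2 (Homo sapiens) (a higher number here means a weaker inhibitor, a lower number a stronger inhibitor), compound 1 gives 1360 nM and compound 2 gives 1240 nM; the step of a 1.1-fold lower number from compound 1 to compound 2 (0.04 log units; within the scatter) is within the scatter, so the two cannot be ordered. Compound 3 gives 370 nM, the lowest of the three numbers; the steps of a 3.7-fold lower number from compound 1 to compound 3 (0.57 log units; beyond the scatter) and a 3.4-fold lower number from compound 2 to compound 3 (0.53 log units; beyond the scatter) are both beyond the scatter, so compound 3 stands apart from the two chain compounds.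

Compound 4 `Cc1ccccc1CSc1nc2ccccc2n1CC(=O)O` differs from compound 3 only by methyl in place of chloro on an aromatic carbon. For the measured compounds named here, none of the measured steps touches this position: the two steps beyond the scatter both replace a chain by the 2-chlorophenyl group as a whole, and the step within the scatter shortens a chain. Going by the values given here, there is therefore no measured step to lean on for a swap on the aromatic ring itself, and the expected step of a 1.1-fold higher number from compound 3 to compound 4 (0.03 log units; within the scatter) is set at nothing beyond the scatter. Compound 4 is estimated at 400 nM, within a range from 150 nM to 1100 nM.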

Compound 4, half-maximal inhibitory concentration: 810 nM
Compound 4: middle estimate off by 2.0-fold (0.31 log units), on the low side; the range from low to high includes it.
By their numbers in this assay, from the lowest: compound 3; then compounds 4, 2 and 1 (each within the scatter of the next).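

In this assay this aromatic carbon, ortho to a large group, is sensitive to the choice of substituent, as methyl in place of chloro gives a step beyond the scatter (a 2.2-fold higher number from compound 3 to compound 4 (0.34 log units; beyond the scatter)). The separation of compound 3 from the chain compounds does not carry over to the 2-methylphenyl group, since both steps to compound 4 are within the scatter (a 1.5-fold lower number from compound 2 to compound 4 (0.18 log units; within the scatter); a 1.7-fold lower number from compound 1 to compound 4 (0.23 log units; within the scatter)), leaving compound 4 unordered against compound 1 and compound 2. Nothing measured here accounts for the difference between chloro and methyl at this position.

The compounds shown leave open where fluoro, bromo, methoxy or trifluoromethyl on the same aromatic carbon would fall relative to chloro and methyl. They also leave open how a plain phenyl group, carrying hydrogen at this carbon, would compare with the 2-chlorophenyl and 2-methylphenyl groups.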